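Swapping a saturated ring for an aromatic one at the amine

The source may report more compounds than this note shows. Statements on the series, on what has been measured and on what is new or still open speak of the compounds shown alone.

Measured so far:
Compound 1, `Clc1ccccc1Cn1nnc2c(NC3CCCC3)ncnc21`: 21 nM
Compound 2, `CC1CCCC(Nc2ncnc3c2nnn3Cc2ccccc2Cl)C1`: 102 nM
Compound 3, `Clc1ccccc1Cn1nnc2c(NCC3CCCCC3)ncnc21`: 4260 nM

In an assay on cell membranes for binding affinity to adenosine receptor A1 (Bos taurus), read by radioligand binding (a higher number here means a weaker inhibitor, a lower number a stronger inhibitor), compound 3 gives the highest number of the three, weaker than compound 2 by a 42-fold higher number from compound 2 to compound 3 (1.62 log units; beyond the scatter) and weaker than compound 1 by a 200-fold higher number from compound 1 to compound 3 (2.31 log units; beyond the scatter). Compound 4, `Cc1ccc(Nc2ncnc3c2nnn3Cc2ccccc2Cl)cc1`, differs from compound 3 by 4-methylphenyl in place of cyclohexylmethyl on a nitrogen on an aromatic ring. Among the compounds with values here, no measured step exchanges a saturated group for an aromatic one, so the measured steps bear on this change only loosely: the cyclopentyl and 3-methylcyclohexyl compounds both bind far more tightly than the cyclohexylmethyl compound, and an aromatic ring has no precedent here. Compound 4 is therefore expected to gain somewhat, a step of a 5.3-fold lower number from compound 3 to compound 4 (0.73 log units; beyond the scatter) in this assay, with wide uncertainty. The estimate for compound 4 is 800 nM, between 150 nM and 4000 nM.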

Compound 4, inhibition constant: 119 nM
Compound 4: middle estimate off by 6.7-fold (0.83 log units), on the high side; the measured number lies below the stated range.
By their numbers in this assay, from the lowest: compound 1; then compounds 2 and 4 (each within the scatter of the next); then compound 3.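

In this assay an aromatic ring on this nitrogen is clearly compatible with binding: the change gives a 36-fold lower number from compound 3 to compound 4 (1.55 log units; beyond the scatter) and, with a 1.2-fold higher number from compound 2 to compound 4 (0.07 log units; within the scatter) as well, the aryl compound cannot be told apart from the 3-methylcyclohexyl one. The cyclopentyl compound keeps its lead, with a 5.7-fold higher number from compound 1 to compound 4 (0.75 log units; beyond the scatter) as the gap. No measurement here accounts for these differences. Still open, from the compounds shown here alone, is whether the ring type or the carbon link in cyclohexylmethyl matters more, since this change alters both. Plain phenyl and benzyl on the same nitrogen would separate those two.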